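This account rests on a few compounds, and the source may have more. Where it says the series, first, only, none or still open, it means among the compounds named here.

Compound 1 `COC(=O)C(C)(C)Nc1cc(CS(=O)(=O)/C=C/c2c(OC)cc(OC)cc2OC)ccc1OC` gives 800 nM
Compound 2 `COc1cc(OC)c(/C=C/S(=O)(=O)Cc2ccc(OC)c(N[C@@H](C)C(=O)O)c2)c(OC)c1` gives 15 nM

In a functional assay on K562 cells (Homo sapiens) for cytotoxicity, read by trypan blue exclusion, with a stated time of 96 h (a lower number here means a stronger inhibitor, a higher number a weaker inhibitor), compound 2 holds the lower of the two numbers. Compound 3 `COc1cc(OC)c(/C=C/S(=O)(=O)Cc2ccc(OC)c(NC(C(=O)O)c3ccc(Cl)cc3)c2)c(OC)c1` differs from it on a nitrogen on an aromatic ring: carboxy(4-chlorophenyl)methyl in place of 1-carboxyethyl on a nitrogen on an aromatic ring. Among the compounds with values here, the only measured step at that place is a 53-fold lower number from compound 1 to compound 2 (1.73 log units; beyond the scatter) and it is large. Compound 3 keeps a carboxy group, so a much smaller step is expected in this assay, though one still toward a higher number and probably beyond the scatter. The expected change is a 4.0-fold higher number from compound 2 to compound 3 (0.60 log units; beyond the scatter) in this estimate. Compound 3 is estimated at 60 nM within an expected range of 15 nM to 300 nM in this assay.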

Compound 3, half-maximal inhibitory concentration: 250 nM
Compound 3: the middle estimate sits 4.2-fold (0.62 log units) below what was measured, and the stated range covers the measured number.
By their numbers in this assay, from the lowest: compound 2; then compound 3; then compound 1.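

In this assay, keeping the carboxy group does not by itself preserve the low number at this nitrogen: both compounds carry one, yet there is a 17-fold higher number from compound 2 to compound 3 (1.22 log units; beyond the scatter), a large step. Compound 3 still reads better than the methoxycarbonyl-bearing compound 1, with a 3.2-fold lower number from compound 1 to compound 3 (0.51 log units; beyond the scatter), though this step is only modest. No measured evidence accounts for either step. The compounds shown do not separate the effect of the chlorine from that of the aromatic ring that carries it, or from the loss of the defined stereocentre. As far as these compounds go, how a plain phenyl or a carboxymethyl group on this nitrogen would read remains open.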